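This account rests on a few compounds, and the source may have more. Where it says the series, first, only, none or still open, it means among the compounds named here.

Measured compounds:
- compound 1, `O=C(c1ccccc1)N1CCC(N(C2CC2)S(=O)(=O)c2cccc(C(F)(F)F)c2)CC1`: "not determined" (no result reported)
- compound 2, `NC(=O)c1ccccc1C(=O)N1CCC(N(C2CC2)S(=O)(=O)c2cccc(C(F)(F)F)c2)CC1`: 11%
- compound 3, `NC(=O)c1cccc(C(=O)N2CCC(N(C3CC3)S(=O)(=O)c3cccc(C(F)(F)F)c3)CC2)c1`: "not determined" (no result reported)

These three compounds share one core and differ only in what sits on the benzoyl ring. The measurement of interest is an assay on cells for inhibition of Voltage-dependent L-type calcium channel subunit alpha-1C (Homo sapiens), read by FLIPR and calcium flux, tested at 1 uM; a lower number here means a weaker effect, a higher number a stronger effect of the compound at the concentration tested. Compound 1 has no number here, since its result was reported as "not determined" (no result reported). Compound 3 is in the same position, with a result of "not determined" (no result reported). Among the measured compounds shown here, the only compound with a figure is compound 2, which gives 11% in this assay, a weak effect at the concentration tested.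

Compound 4, `CN(C)c1cccc(C(=O)N2CCC(N(C3CC3)S(=O)(=O)c3cccc(C(F)(F)F)c3)CC2)c1`, is not yet measured. It differs from compound 1 in one place: dimethylamino in place of hydrogen on an aromatic carbon. The change sits on an aromatic carbon of a six-membered aromatic ring of carbon only, meta to a large group.

For the measured compounds named here, with no step between measured compounds to lean on, and only the weak value of compound 2 in this assay as a guide, no step beyond the scatter is expected from compound 1 to compound 4 in this assay. Compound 4 is expected to give 15%, within a range of 0% to 40%.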

Compound 4, a percentage reported as inhibition, at one concentration (the size of the read-out at that concentration, not a potency): 40%
Beside the measured number, compound 4's estimate is 25 percentage points below it, and the stated range covers the measured number.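

In this assay, the group on the benzoyl ring can change the read-out: a number 29 percentage points higher from compound 2 to compound 4 (beyond the scatter), with 3-(dimethylamino)phenyl in place of 2-carbamoylphenyl on the carbonyl carbon. This single step swaps both the group and its place on the ring, so it cannot show which of the two matters, and the effect of dimethylamino alone cannot be read, as compound 1 has no number to compare with. No measurement shown accounts for the step.

As far as these compounds go, whether dimethylamino is needed for this higher read-out stays open, as a primary amine, a methoxy group or a pyrrolidine at the same place would test this. A carboxylic acid there would show whether other groups on this ring also move the read-out in this assay.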